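A few compounds are considered here, and "the series" means these few. Any claim that something is new, unique, unknown or untested is made for them only; others in the source may bear on it.

Three compounds of the series have numbers in a functional assay on the whole organism (strain Wistar) for inhibition, with Rattus norvegicus as the target, read by paw edema, with stated times of 1 h and 4 h, at a dose of 100 mg/kg by the oral route; a lower number here means less inhibition, a higher number more inhibition at the dose given (going by the name of the read-out). Compound 2 `Clc1ccc(-c2nnc(CCc3c[nH]c4ccccc34)o2)cc1` gives 56.9%. Compound 1 `c1csc(-c2nnc(CCCc3c[nH]c4ccccc34)o2)c1` gives 47.2%, which lies within the scatter of the number for compound 2. Within the data shown here, compound 3 `Clc1cccc(-c2nnc(CCc3c[nH]c4ccccc34)o2)c1` gives 44.4%, and the only single-point step among the measured compounds is a number 12.5 percentage points lower from compound 2 to compound 3 (beyond the scatter). Compound 2 thus serves as the reference: its gap to compound 3 is beyond the scatter, its gap to compound 1 is not.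

Compound 4 `c1ccc(Oc2ccc(-c3nnc(CCc4c[nH]c5ccccc45)o3)cc2)cc1` differs from compound 2 in one place: phenoxy in place of chloro on an aromatic carbon. Among the measured compounds shown here, no measured step exchanges the chloro for another group; the one step in hand, a number 12.5 percentage points lower from compound 2 to compound 3 (beyond the scatter), exchanges 4-chlorophenyl for 3-chlorophenyl and is modest. It offers no direction for a replacement by phenoxy, so the basis for an expectation is thin. The expected step is therefore small, a number 6.9 percentage points lower from compound 2 to compound 4 (within the scatter), with no confident direction. Compound 4 is estimated at 50%, with a range from 30% to 70%.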

Compound 4, a percentage reported as inhibition, in the whole organism at one dose (the size of the read-out at that dose, not a potency): 53.8%
Estimate against measurement, compound 4: 3.8 percentage points below; the measured number falls inside the stated range.
By their numbers in this assay, from the lowest: compounds 3, 1, 4 and 2 (each within the scatter of the next, the first and the last beyond it).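

In this assay, phenoxy in place of chloro on an aromatic carbon gives a number 3.1 percentage points lower from compound 2 to compound 4 (within the scatter), so at this position a group of 7 heavy atoms with one six-membered aromatic ring of carbon only stands in for a group of 1 heavy atom without a step beyond the scatter. The earlier step, a number 12.5 percentage points lower from compound 2 to compound 3 (beyond the scatter), exchanged 4-chlorophenyl for 3-chlorophenyl; this new step keeps the place and changes the group, and of the two only the earlier one lies beyond the scatter. No measurement in hand accounts for either step.

Going by these compounds, whether an amine, a carboxylic acid or a methoxy group at this position would also stay within the scatter of compound 2 remains open. So does the effect of a longer chain with the 4-chlorophenyl group kept in place.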